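The source may report more compounds than this note shows. Statements on the series, on what has been measured and on what is new or still open speak of the compounds shown alone.

Measured compounds in an ADME assay on HEK293 cells (Homo sapiens) for cytotoxicity, read by CellTiter-Glo and resazurin assay, with a stated time of 72 h; on this read-out higher numbers stand for an effect only at larger amounts of compound and lower numbers for an effect already at smaller amounts:
Compound 1 `CC(C)N(Cc1cccc(OCCCCCC(=O)O)c1)C(=O)c1ccc(-c2cccc3ccccc23)cc1` – > 26000 nM, a limit of the assay.
Compound 2 `CC(=O)c1cccc(-c2ccc(C(=O)N(Cc3cccc(OCCCCCC(=O)O)c3)C(C)C)cc2)c1` – > 26000 nM, a limit of the assay.
Compound 3 `COc1ccc(F)c(-c2ccc(C(=O)N(Cc3cccc(OCCCCCC(=O)O)c3)C(C)C)cc2)c1` – > 26000 nM, a limit of the assay.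

Compound 2 stands on a limit only, and the two further values shown are limits as well, so no order among the three compounds can be read. The steps a step that the two limits leave unreadable from compound 1 to compound 2, a step that the two limits leave unreadable from compound 1 to compound 3 and a step that the two limits leave unreadable from compound 2 to compound 3 are all unreadable for the same reason, which is summed up by the limit of > 26000 nM in this assay, at which 3 of the 3 values shown sit.

Compound 4 `CC(C)N(Cc1cccc(OCCCCCC(=O)O)c1)C(=O)c1ccc(-c2cccc(Cl)c2)cc1` is not yet measured. It differs from compound 2 as follows: chloro in place of acetyl on an aromatic carbon. Within the data shown here, no measured step bears directly on the exchange of acetyl for chloro; the steps at hand concern the other aryl group and are all unreadable. Three limits at the same ceiling are the whole evidence, and they suggest that compound 4 will again reach that ceiling. For compound 4 the estimate is 40000 nM (range 15000 nM to 100000 nM). The step that the limit leaves unreadable from compound 2 to compound 4 is expected to be none beyond the scatter.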

Compound 4, half-maximal effective concentration: > 21900 nM
Compound 4 was reported as a limit; the forecaster's own chance of this, stated with the estimate: 85%; the middle value lies beyond the limit too.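

In this assay compound 4 gives > 21900 nM, a limit of the assay. Among these compounds, all values are limits, so no step among compound 1, compound 2, compound 3 and compound 4 can be read. Left open: the concentration, if any, at which any of these four compounds reaches a half-maximal effect in this assay, and whether their aryl groups differ there at all.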